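A Halogen Swap on the Amide Ring of Compound 1

A few compounds are considered here, and "the series" means these few. Any claim that something is new, unique, unknown or untested is made for them only; others in the source may bear on it.

Compound 1 `O=C(Nc1ccc(S(=O)(=O)Nc2ccccc2)cc1)c1cc(F)c(Cl)cc1F`: 141 nM
Compound 2 `O=C(Nc1cccc(S(=O)(=O)Nc2ccccc2)c1)c1ccc(Cl)cc1Cl`: > 100000 nM

Of the compounds shown here, two have been tested in a functional assay on HEK293 cells for agonist activity at probable G-protein coupled receptor 27 (Homo sapiens), read by a luciferase reporter and beta-arrestin recruitment, with a stated time of 10 min; a higher number here means that more compound is needed for the effect, a lower number that less compound is needed. Among the compounds with values here, compound 1 is the only one with a definite number, giving 141 nM in this assay. Compound 2 is recorded only as the limit of > 100000 nM in this assay, at which 1 of the 2 values shown sits, a limit rather than a measured number. The two compounds differ in more than one place, so nothing can be said about any single change between them.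

Compound 3 `O=C(Nc1ccc(S(=O)(=O)Nc2ccccc2)cc1)c1ccc(I)cc1F` is not yet measured. It keeps the shared core of compound 1 and changes only the ring on the carbonyl carbon: 2-fluoro-4-iodophenyl in place of 4-chloro-2,5-difluorophenyl on a carbonyl carbon. Within the data shown here, with no measured step of this kind to lean on, only a modest shift is expected, and its direction is uncertain; the change is taken as roughly neutral, with a slight lean toward needing a little more compound. The step from compound 1 to compound 3 is therefore estimated at a 1.6-fold higher number from compound 1 to compound 3 (0.19 log units; within the scatter). Compound 3 is expected to give 220 nM in this assay, most likely between 50 nM and 1200 nM.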

Compound 3, half-maximal effective concentration: 5130 nM
For compound 3 the middle estimate is 23-fold (1.37 log units) below the measured one; the measured number lies above the stated range.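

This is the first step shown that changes one place only, the ring on the carbonyl carbon, and in this assay it amounts to a 36-fold higher number from compound 1 to compound 3 (1.56 log units; beyond the scatter), well beyond the usual scatter. The halogens on this ring are therefore not freely interchangeable: with the shared core held fixed, putting 2-fluoro-4-iodophenyl in place of 4-chloro-2,5-difluorophenyl means far more compound is needed for the effect. No measurement shown offers a reason for this step.

The swap bundles two changes, the loss of one fluorine and iodine replacing chlorine, and the compounds shown leave open which of them carries the step. Also open, from the compounds shown here alone, is how a ring bearing bromine or a methoxy group where the iodine sits would read in this assay.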